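The source may report more compounds than this note shows. Statements on the series, on what has been measured and on what is new or still open speak of the compounds shown alone.

Compound 1 `COc1ccc(N(C)c2ccnc(Cl)n2)cc1F`: 651 nM
Compound 2 `COc1ccc(N(C)c2ccnc(Cl)n2)cc1O`: 381 nM

Both values come from a functional assay on A549 cells (Homo sapiens) for antiproliferative activity, read by MTT assay, with a stated time of 48 h; a higher number here means a weaker inhibitor, a lower number a stronger inhibitor. Among the measured compounds shown here, compound 2 stands level with compound 1, the only other measured compound, as the one step between them is a 1.7-fold lower number from compound 1 to compound 2 (0.23 log units; within the scatter). Compound 3 `COc1ccc(N(C)c2ccnc(Cl)n2)cc1OCCBr` departs from compound 2 by 2-bromoethyl in place of hydrogen on an oxygen on an aromatic ring, which turns hydroxy into 2-bromoethoxy. The step to compound 2 exchanged fluoro for hydroxy on an aromatic carbon, so it bears only loosely on this change. For the measured compounds named here, no measured step tests a group added on that oxygen. The expectation is therefore a modest move towards a higher number, probably not beyond the scatter, and its direction is weakly supported. An estimated 1.6-fold higher number from compound 2 to compound 3 (0.20 log units; within the scatter) is the expected result. For compound 3 the expected value is 600 nM, with an estimated range of 150 nM to 2500 nM.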

Compound 3, half-maximal inhibitory concentration: 4640 nM
Estimate against measurement, compound 3: 7.7-fold (0.89 log units) below; measured number outside the range, above it.
By their numbers in this assay, from the lowest: compounds 2 and 1 (each within the scatter of the next); then compound 3.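

In this assay, among the compounds shown here, 2-bromoethyl on the oxygen of the hydroxy group gives the first step that lies beyond the scatter (a 12-fold higher number from compound 2 to compound 3 (1.09 log units; beyond the scatter)). The number at this position therefore depends on the group it carries, and the comparison with the fluoro compound agrees (a 7.1-fold higher number from compound 1 to compound 3 (0.85 log units; beyond the scatter)), whereas fluoro and hydroxy stood within the scatter of each other. No measurement at hand explains the step to 2-bromoethoxy.

The compounds shown do not separate the contribution of the bromine from that of the ethyl chain, or from that of replacing the hydrogen on the oxygen. Open comparisons on that oxygen are a plain methyl, a 2-hydroxyethyl or 2-aminoethyl chain, and a longer chain ending in bromine.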